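The source may report more compounds than this note shows. Statements on the series, on what has been measured and on what is new or still open speak of the compounds shown alone.

Measured in a functional assay on HCT-116 cells (Homo sapiens) for inhibition, read by CCK-8 assay, with a stated time of 48 h; a higher number here means a weaker inhibitor, a lower number a stronger inhibitor:

- compound 1 `COc1cc(-c2ccnc3cc(-c4ccc(C)c(C)c4)nn23)cc(OC)c1OC`: 261 nM
- compound 2 `COc1cc(-c2ccnc3cc(-c4ccc5c(ccn5C)c4)nn23)cc(OC)c1OC`: 39 nM
- compound 3 `COc1cc(-c2ccnc3cc(-c4ccc5cc[nH]c5c4)nn23)cc(OC)c1OC`: 187 nM

For the measured compounds named here, of these three numbers, the one for compound 3 is level with that of compound 1 within the scatter and higher than that of compound 2. The measured steps show this: a 1.4-fold lower number from compound 1 to compound 3 (0.14 log units; within the scatter), and a 4.8-fold higher number from compound 2 to compound 3 (0.68 log units; beyond the scatter). The largest step in the set is a 6.7-fold lower number from compound 1 to compound 2 (0.83 log units; beyond the scatter).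

Compound 4 `COc1cc(-c2ccnc3cc(-c4ccc(C(C)=O)cc4)nn23)cc(OC)c1OC` carries 4-acetylphenyl in place of 1H-indol-6-yl on an aromatic carbon.

The closest measured comparison is compound 1, which also carries a substituted phenyl and gives 261 nM. Going by the values given here, no measured compound carries an acetyl group, so the data do not show what it contributes. Little change is therefore expected in this assay, with a slight lean towards a higher number, and the range stays wide. The expected step is a 1.3-fold higher number from compound 3 to compound 4 (0.13 log units; within the scatter). For compound 4 the estimated value is 250 nM, with an expected range from 80 nM to 800 nM.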

Compound 4, half-maximal inhibitory concentration: 4390 nM
Compound 4: middle estimate off by 18-fold (1.24 log units), on the low side, outside the stated range (above it).
By their numbers in this assay, from the lowest: compound 2; then compounds 3 and 1 (each within the scatter of the next); then compound 4.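

In this assay, for the compounds shown here, this aromatic carbon of the five-membered ring proves far less forgiving than the earlier compounds suggested, since 4-acetylphenyl makes compound 4 the weakest of the set, with a 23-fold higher number from compound 3 to compound 4 (1.37 log units; beyond the scatter), a 110-fold higher number from compound 2 to compound 4 (2.05 log units; beyond the scatter) and a 17-fold higher number from compound 1 to compound 4 (1.23 log units; beyond the scatter). The last of these steps shows that carrying a substituted phenyl does not by itself keep the number low, as compound 1 and compound 4 both have one and still lie far apart. Nothing available here accounts for the size of this loss.

As far as these compounds go, compound 1 and compound 4 differ in both the substituents on the phenyl ring and where they stand, so the acetyl group's own share remains open. Also open, from the compounds shown here alone, is whether 4-aminophenyl or 4-carboxyphenyl in the same place would give a number nearer that of compound 4 or that of compound 1.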